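Aryl urea quinazoline amines: methyl-to-chloro swap

A few compounds are considered here, and "the series" means these few. Any claim that something is new, unique, unknown or untested is made for them only; others in the source may bear on it.

Measured so far in a functional assay on A549 cells (Homo sapiens) for antiproliferative activity, read by MTT assay; a higher number here means a weaker inhibitor, a lower number a stronger inhibitor:
compound 1 `Cc1cccc(NC(=O)Nc2cccc(CNc3ncnc4ccccc34)c2)c1` gives 30200 nM
compound 2 `O=C(Nc1cccc(CNc2ncnc3ccccc23)c1)Nc1cccc(C(F)(F)F)c1` gives 44200 nM
compound 3 `COc1cc2ncnc(NCc3cccc(NC(=O)Nc4cccc(C)c4)c3)c2cc1OC` gives 27100 nM

Compound 3 carries the dimethoxy-substituted core; its value is within the scatter of both compound 1 and compound 2, so the three cannot be separated on these numbers. Going by the values given here, the one step between compounds that differ in one place, a 1.5-fold higher number from compound 1 to compound 2 (0.17 log units; within the scatter), is also within the scatter.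

Compound 4 `COc1cc2ncnc(NCc3cccc(NC(=O)Nc4ccc(Cl)cc4)c3)c2cc1OC` is compound 3 with 4-chlorophenyl in place of 3-methylphenyl on an amide-type nitrogen. Among the compounds with values here, no measured pair covers this change. Within the data shown here, the only step that bears on it, a 1.5-fold higher number from compound 1 to compound 2 (0.17 log units; within the scatter), is a change on the same aryl ring of the urea and produced no shift beyond the scatter. On that basis compound 4 is expected to show no step beyond the scatter in this assay, and the step from compound 3 is estimated as a 1.0-fold lower number from compound 3 to compound 4 (0.00 log units; within the scatter). The value expected for compound 4 is 27000 nM, with a range from 11000 nM to 65000 nM.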

Compound 4, half-maximal inhibitory concentration: 30400 nM
Compound 4: the middle estimate sits 1.1-fold (0.05 log units) below what was measured; the measured number falls inside the stated range.
By their numbers in this assay, from the lowest: compounds 3, 1, 4 and 2 (each within the scatter of the next).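

In this assay, 4-chlorophenyl in place of 3-methylphenyl on the amide-type nitrogen gives a 1.1-fold higher number from compound 3 to compound 4 (0.05 log units; within the scatter), so this exchange on the dimethoxy-substituted core produces no step beyond the scatter. With a 1.5-fold higher number from compound 1 to compound 2 (0.17 log units; within the scatter) on the core of compound 1, the urea aryl ring now has two single-place changes on two different cores, neither beyond the scatter. No independent measurement is available to account for these small steps.

From the compounds shown here alone, it remains open whether an amine or a carboxylic acid on this aryl ring, or a longer chain in its place, would give a step beyond the scatter in this assay. A 3-chlorophenyl group on the same core would separate the change of group from the change of its printed ring position.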